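Shrinking the aryl group on a shared ribonucleoside core

The compounds below may be only part of what the source reports. "The series", "measured", "known", "first", "only" and "open" are said of these compounds alone.

Compound 1, `COc1ncnc2c1c(-c1ccsc1)cn2[C@@H]1O[C@H](CO)[C@@H](O)[C@H]1O`, gives 5170 nM in a functional assay on A549 cells (Homo sapiens), read by MTT assay, with a stated time of 72 h; on this read-out higher numbers stand for weaker inhibition and lower numbers for stronger inhibition.
Compound 2, `COc1nc(N)nc2c1c(-c1ccco1)cn2[C@@H]1O[C@H](CO)[C@@H](O)[C@H]1O`, gives only a limit of the assay, > 20000 nM, in this assay.
Compound 3, `COc1ncnc2c1c(-c1cc3ccccc3o1)cn2[C@@H]1O[C@H](CO)[C@@H](O)[C@H]1O`, gives 17700 nM in this assay.

Among the two numbers that are not limits, compound 3 stands highest; its nearest neighbour is compound 1, and a 3.4-fold higher number from compound 1 to compound 3 (0.53 log units; beyond the scatter). The limit for compound 2 is noted as the limit of > 20000 nM in this assay, at which 1 of the 3 values shown sits, and yields no number to compare.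

Compound 4, `COc1ncnc2c1c(-c1ccco1)cn2[C@@H]1O[C@H](CO)[C@@H](O)[C@H]1O`, is not yet measured. Its change from compound 3 is furan-2-yl in place of 1-benzofuran-2-yl on an aromatic carbon. For the measured compounds named here, the one measured step that bears on it is the move from a small five-membered aryl group to the larger fused one, a 3.4-fold higher number from compound 1 to compound 3 (0.53 log units; beyond the scatter), which raised the number by a modest amount. Compound 4 runs the other way, back to a small five-membered aryl group, so a modest fall in this assay is expected for compound 4, roughly the reverse of that step, with wide uncertainty since compound 2, a furan-2-yl compound, reached only a limit.

Compound 4 is therefore expected to give about 7000 nM in this assay, between 2500 nM and 20000 nM, an estimated step of a 2.5-fold lower number from compound 3 to compound 4 (0.40 log units; beyond the scatter).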

Compound 4, half-maximal inhibitory concentration: 30 nM
Beside the measured number, compound 4's estimate is 230-fold (2.37 log units) above it; measured number outside the range, below it.
By their numbers in this assay, from the lowest: compound 4; then compound 1; then compound 3. At a limit, above all of these: compound 2.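

In this assay, for the compounds shown here, the group at this position, two ring bonds from the ring nitrogen, proves far more decisive than the earlier compounds suggested: removing the six-membered aromatic ring from 1-benzofuran-2-yl gives a 590-fold lower number from compound 3 to compound 4 (2.77 log units; beyond the scatter), and furan-2-yl in place of thiophen-3-yl gives a 170-fold lower number from compound 1 to compound 4 (2.24 log units; beyond the scatter). As thiophen-3-yl and furan-2-yl each carry one five-membered aromatic ring, ring count alone does not set the number here. With furan-2-yl held fixed, hydrogen in place of amino gives an at least 660-fold lower number from compound 2 to compound 4 (2.82 log units; beyond the scatter), a step that starts from a limit rather than a number: the limit of > 20000 nM in this assay, at which 1 of the 4 values shown sits.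

As far as these compounds go, it remains open whether this result extends to other small rings at this position, such as thiophen-2-yl or pyrrol-2-yl. From the compounds shown here alone, it also remains open how replacing the methoxy group with an amine would change the number.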